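A few compounds are considered here, and "the series" means these few. Any claim that something is new, unique, unknown or untested is made for them only; others in the source may bear on it.

In an assay on isolated protein (strain Sprague-Dawley) for inhibition of Amine oxidase [flavin-containing] B (Rattus norvegicus), read by spectrophotometry, with a stated time of 5 min (a lower number here means a stronger inhibitor, a higher number a weaker inhibitor), three compounds have been measured so far:

compound 1 `COc1cc(=O)oc2cc(OCc3cccc(F)c3)ccc12` gives 36.3 nM;
compound 2 `CN(C)C(=O)COc1cc(=O)oc2cc(OCc3cccc(Cl)c3)ccc12` gives 501 nM;
compound 3 `O=c1cc(CO)c2ccc(OCc3cccc(Br)c3)cc2o1` gives 14.1 nM.

Compound 2 stands highest of these three numbers. Its nearest neighbour is compound 1, whose number is lower by a gap beyond the scatter, and compound 3 lies furthest, lower still and also beyond the scatter. Among the measured compounds shown here, no single-point step between measured compounds is available, so the next compound is judged from the structures alone.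

Compound 4 `O=Cc1cc(=O)oc2cc(OCc3cccc(Cl)c3)ccc12` differs from compound 2 in one place: formyl in place of (dimethylcarbamoyl)methoxy on an aromatic carbon. The step from compound 2 to compound 4 is expected to be downward in this assay and beyond the scatter, because compound 1 gives 36.3 nM and compound 3 gives 14.1 nM while carrying groups of few heavy atoms, closer in size to formyl. The expected step is a 13-fold lower number from compound 2 to compound 4 (1.10 log units; beyond the scatter). Compound 4 is therefore estimated at 40 nM, with a range from 8 nM to 200 nM.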

Compound 4, half-maximal inhibitory concentration: 52.5 nM
Estimate against measurement, compound 4: 1.3-fold (0.12 log units) below; the range from low to high includes it.
By their numbers in this assay, from the lowest: compound 3; then compounds 1 and 4 (each within the scatter of the next); then compound 2.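

In this assay, among the compounds shown here, putting formyl in place of (dimethylcarbamoyl)methoxy on this aromatic carbon, opposite the ring oxygen, gives a 9.5-fold lower number from compound 2 to compound 4 (0.98 log units; beyond the scatter) and is the first single change that can be read in this set. At this position, the group of 2 heavy atoms therefore gives a lower number than the group of 7 heavy atoms. Nothing available explains the step. This one pair cannot separate the effect of size from the loss of the amide. As far as these compounds go, whether a carboxylic acid, an aminomethyl group or a longer chain at this carbon would fall nearer compound 4 or compound 2 remains open.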